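The source may hold more compounds than are shown below. What is called first, only, known or untested is meant among the compounds shown, and "the series" means these compounds.

In an assay on HEK293 cells for agonist activity at transient receptor potential cation channel subfamily M member 8 (Homo sapiens), read by fluorescence and calcium flux, with a stated time of 15 min (on this read-out higher numbers stand for an effect only at larger amounts of compound and lower numbers for an effect already at smaller amounts), compound 3 `Cc1ccc(OCC(=O)N(Cc2cccs2)c2nccs2)cc1` gives 2240 nM, the highest number among the three compounds measured. Compound 1 `Cc1ccc(OCC(=O)N(Cc2cccs2)c2ncco2)cc1` gives 0.3 nM and compound 2 `CON(Cc1cccs1)C(=O)COc1ccc(C)cc1` gives 10 nM in this assay. Compound 4 `Cc1ccc(OCC(=O)N(Cc2cccs2)C2COC2)cc1` differs from compound 3 by oxetan-3-yl in place of 1,3-thiazol-2-yl on an amide-type nitrogen. Within the data shown here, two measured steps bear on this change: a 7500-fold higher number from compound 1 to compound 3 (3.87 log units; beyond the scatter) and a 220-fold higher number from compound 2 to compound 3 (2.35 log units; beyond the scatter), both showing that the thiazolyl group on this nitrogen carries a much higher number than either of the two other groups tried. Compound 4 exchanges that group for a small non-aromatic ring, so a large fall in number is expected, estimated as a 75-fold lower number from compound 3 to compound 4 (1.87 log units; beyond the scatter). Compound 4 is therefore expected to give about 30 nM in this assay, within a range from 3 nM to 400 nM.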

Compound 4, half-maximal effective concentration: 23000 nM
The estimate for compound 4 lay 770-fold (2.88 log units) below the measured number; measured number outside the range, above it.
By their numbers in this assay, from the lowest: compound 1; then compound 2; then compound 3; then compound 4.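

Until now, 1,3-thiazol-2-yl carried the highest number on this amide-type nitrogen, but oxetan-3-yl goes further, with a 10-fold higher number from compound 3 to compound 4 (1.01 log units; beyond the scatter). The gaps to the other two groups are wider still, with a 2300-fold higher number from compound 2 to compound 4 (3.36 log units; beyond the scatter) and a 77000-fold higher number from compound 1 to compound 4 (4.88 log units; beyond the scatter), so swapping an aromatic ring for this small non-aromatic ring did not bring the number down. Nothing measured here explains these differences. Going by these compounds, it remains open whether a cyclobutyl ring, which has carbon in place of the oxetane oxygen, or an open methoxyethyl chain would behave like oxetan-3-yl or more like methoxy.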